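Hydrazone series on HepG2: from compound 2 to compound 3

A few compounds are considered here, and "the series" means these few. Any claim that something is new, unique, unknown or untested is made for them only; others in the source may bear on it.

Two members of this series have numbers in a functional assay on HepG2 cells (Homo sapiens) for cytotoxicity, read by MTT assay, with a stated time of 48 h; a higher number here means a weaker inhibitor, a lower number a stronger inhibitor. Compound 1 `O=C(CSc1nnc(-c2ccncc2)o1)N/N=C/c1cccc(C(F)(F)F)c1` gives 6520 nM. Compound 2 `O=C(CSc1nnc(-c2ccncc2)o1)N/N=C/c1ccccc1[N+](=O)[O-]` gives 24700 nM, the highest of the two numbers, and its gap to compound 1 lies beyond the scatter. Compound 3 `O=C(CSc1nnc(-c2ccncc2)o1)N/N=C/C=C/c1ccccc1` is the untested analogue; it differs from compound 2 in one place: 2-phenylethenyl in place of 2-nitrophenyl on a carbon with a double bond to nitrogen. For the measured compounds named here, no measured pair shows this change, so the size of the step is open. A modest move toward a lower number is expected, a 2.2-fold lower number from compound 2 to compound 3 (0.35 log units; beyond the scatter), though it could stay within the scatter. Compound 3 is expected to give about 11000 nM, within 3500 nM to 35000 nM.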

Compound 3, half-maximal inhibitory concentration: 7420 nM
For compound 3 the middle estimate is 1.5-fold (0.17 log units) above the measured one, within the range that was stated.
By their numbers in this assay, from the lowest: compounds 1 and 3 (each within the scatter of the next); then compound 2.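

On the carbon with a double bond to nitrogen, 2-phenylethenyl in place of 2-nitrophenyl gives the first step readable at this position in this assay (a 3.3-fold lower number from compound 2 to compound 3 (0.52 log units; beyond the scatter)). Compound 3 gives 7420 nM and compound 1 gives 6520 nM, which lie within the scatter of each other, so two different groups at this place share one level. Nothing at hand accounts for the step. On these data alone, whether a longer chain or an amine in place of 2-phenylethenyl on that carbon would shift the number remains open.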